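A few compounds are considered here, and "the series" means these few. Any claim that something is new, unique, unknown or untested is made for them only; others in the source may bear on it.

Measured compounds:
compound 1 `CC(=O)c1ccc(NC(=O)C(CC(C)C)N(C(=O)c2ccccc2)S(=O)(=O)c2ccc(C)cc2)cc1` — 58.1%
compound 2 `CC(=O)c1ccc(NC(=O)C2CC(O)CN2S(=O)(=O)c2ccc(C)cc2)cc1` — 12.5%
compound 3 `CC(=O)c1ccc(NC(=O)C(CC(C)C)N(C(=O)c2ccccc2)S(=O)(=O)c2ccc([N+](=O)[O-])cc2)cc1` — 54.2%

All three numbers come from a functional assay for inhibition, read by spectrophotometry, with a stated time of 20 min, tested at 2 mg/mL; on this read-out higher numbers stand for a stronger effect at the one concentration tested and lower numbers for a weaker effect. Compound 2 gives the lowest of the three: compound 3 stands higher by a margin beyond the scatter, and compound 1 higher still, also beyond the scatter.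

Compound 4 `CC(=O)c1ccc(NC(=O)C2CC(O)CN2S(=O)(=O)c2ccccc2)cc1` has not yet been measured. It differs from compound 2 in one place: hydrogen in place of methyl on an aromatic carbon. Going by the values given here, no measured pair reproduces this exact change. Among the compounds with values here, the only single-place step in hand is a number 3.9 percentage points lower from compound 1 to compound 3 (within the scatter), which alters the group on the same aromatic carbon of the same ring, though on a different core, and it lies within the scatter. That step suggests the group at this place can be exchanged without moving the number, but the groups involved there are not those of the present change, so it bears on compound 4 only loosely. Within the data shown here, with no measured step pointing in either direction, a change beyond the scatter is not expected. The expected step of a number 0.5 percentage points higher from compound 2 to compound 4 (within the scatter) is accordingly small. Compound 4 is estimated to give 13%, with a range from 3% to 28%.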

Compound 4, a percentage reported as inhibition, at one concentration (the size of the read-out at that concentration, not a potency): 45%
The estimate for compound 4 lay 32 percentage points below the measured number; the measured number lies above the stated range.
By their numbers in this assay, from the lowest: compound 2; then compounds 4, 3 and 1 (each within the scatter of the next, the first and the last beyond it).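

In this assay, going from 4-methylphenyl to phenyl gives a number 32.5 percentage points higher from compound 2 to compound 4 (beyond the scatter), so on the core of compound 2 this aromatic carbon, para to a large group, is not indifferent to what it carries, and a single methyl is enough to separate the two numbers by more than the scatter. The earlier step, a number 3.9 percentage points lower from compound 1 to compound 3 (within the scatter), had shown no such sensitivity, but it lies on a different core and exchanges methyl for nitro, so these two steps alone cannot say whether the core or the entering group sets the difference. No measurement shown bears on the reason for the large step.

The compounds shown leave open whether the high number on this core requires hydrogen at this carbon or would hold with a fluorine atom, a chlorine atom or a methoxy group there, and whether a nitro group would behave here as it does on the core of compound 1. Also open, on these data alone, is whether hydrogen in place of methyl on the core of compound 1 would produce a step of similar size.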